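Methyl in Place of Chloro Among Compounds Held at a Limit

A few compounds are considered here, and "the series" means these few. Any claim that something is new, unique, unknown or untested is made for them only; others in the source may bear on it.

Four compounds share an acyl sulfonylurea linkage between a benzylic amine and a para-substituted benzenesulfonyl group. Compound 1 `CCOc1ccc(F)cc1C(C)NC(=O)NS(=O)(=O)c1ccc(C)cc1` and compound 2 `CCOc1ccc(F)cc1C(C)NC(=O)NS(=O)(=O)c1ccc(Cl)cc1` carry one core, compound 3 `COc1ccc(OC)c(CNC(=O)NS(=O)(=O)c2ccc(Cl)cc2)c1` and compound 4 `COc1ccc(OC)c(CNC(=O)NS(=O)(=O)c2ccc(C)cc2)c1` another; the difference between the two cores is not broken down here.

In a functional assay on thoracic aorta (Rattus norvegicus, strain Wistar), with a stated time of 15 min (a lower number here means that less compound is needed, a higher number that more compound is needed for the effect), compound 1 gives > 300000 nM, which is a limit of the assay. Compound 2 gives > 300000 nM in this assay, also a limit. Compound 3 gives > 300000 nM in this assay, again a limit. The change methyl in place of chloro on an aromatic carbon therefore yields a step that the two limits leave unreadable from compound 2 to compound 1.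

Compound 4 differs from compound 3 by the same change, (methyl in place of chloro on an aromatic carbon). Because (the limit of > 300000 nM in this assay, at which 3 of the 3 values shown sit), nothing in the measured pair separates methyl from chloro, and the change on the other core left both compounds at that limit. The step from compound 3 to compound 4 in this assay is expected to be a number no higher from compound 3 to compound 4 (the limit leaves the size open). Compound 4 is thus estimated at 300000 nM in this assay, most likely reported only as a limit again, with a range from 100000 nM to 1000000 nM.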

Compound 4, half-maximal effective concentration: > 300000 nM
Compound 4: only a limit was reported; the forecaster's own chance of this, stated with the estimate: 85%; the middle value sits exactly at the limit.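

Compound 3 and compound 4 both stand only as limits in this assay, so no new step can be read from this pair: the limit of > 300000 nM in this assay, at which 4 of the 4 values shown sit. The compounds shown leave open whether methyl and chloro differ at all in this read-out on either core, since no compound here has a value that is a number.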